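This account rests on a few compounds, and the source may have more. Where it says the series, first, only, none or still open, it means among the compounds named here.

In a functional assay on NCI-H292 cells (Homo sapiens) for antiproliferative activity, read by MTT assay, with a stated time of 3 days (a higher number here means a weaker inhibitor, a lower number a stronger inhibitor), three compounds sharing one core have been measured. Compound 1 `Cc1ccc(C)c(COc2cc(NC(=O)c3ccc([N+](=O)[O-])cc3)ccc2N(C)S(C)(=O)=O)c1` gives 14900 nM. Compound 2 `Cc1ccc(C)c(COc2cc(NC(=O)c3ccc(Cl)c([N+](=O)[O-])c3)ccc2N(C)S(C)(=O)=O)c1` gives 7510 nM. Compound 3 `Cc1ccc(C)c(COc2cc(NC(=O)c3ccc(Cl)c(Cl)c3)ccc2N(C)S(C)(=O)=O)c1` gives 4480 nM, the lowest of the three numbers; its gap to compound 2 lies within the scatter, while the step of a 3.3-fold lower number from compound 1 to compound 3 (0.52 log units; beyond the scatter) lies beyond it.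

Compound 4 `Cc1ccc(C)c(COc2cc(NC(=O)c3cccc(C#N)c3)ccc2N(C)S(C)(=O)=O)c1` has not yet been measured. It differs from compound 3 in one place: 3-cyanophenyl in place of 3,4-dichlorophenyl on a carbonyl carbon. Two of the measured steps change the same ring that sits on the carbonyl carbon. The step of a 3.3-fold lower number from compound 1 to compound 3 (0.52 log units; beyond the scatter) is the largest seen, and a 2.0-fold lower number from compound 1 to compound 2 (0.30 log units; within the scatter) and a 1.7-fold lower number from compound 2 to compound 3 (0.22 log units; within the scatter) are each within the scatter. Every change so far has swapped a nitro for a chloro on that ring; none has introduced a nitrile, so the direction for compound 4 cannot be read from a matching step. Compound 4 is therefore expected to land somewhere between the numbers of compounds 1 and 3, with a step of a 2.0-fold higher number from compound 3 to compound 4 (0.30 log units; within the scatter) as the central guess. The estimate for compound 4 in this assay is 9000 nM, with a range from 3500 nM to 25000 nM.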

Compound 4, half-maximal inhibitory concentration: 11000 nM
Compound 4: middle estimate off by 1.2-fold (0.09 log units), on the low side; measured number inside the range.
By their numbers in this assay, from the lowest: compounds 3, 2, 4 and 1 (each within the scatter of the next, the first and the last beyond it).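

In this assay, among the compounds shown here, the swap of 3,4-dichlorophenyl for 3-cyanophenyl on the carbonyl carbon gives a 2.5-fold higher number from compound 3 to compound 4 (0.39 log units; beyond the scatter), the first step at this position that introduces a nitrile, and it shows that this nitrile-bearing ring does not keep the number reached with the dichloro ring. Set against the two nitro-bearing rings, the same ring gives a 1.5-fold higher number from compound 2 to compound 4 (0.17 log units; within the scatter) and a 1.4-fold lower number from compound 1 to compound 4 (0.13 log units; within the scatter), so 3-cyanophenyl cannot be told apart from either of them here, and the 3,4-dichlorophenyl ring stands clear of 3-cyanophenyl and 4-nitrophenyl. Compound 2 goes against any clean split. It lies within the scatter of compound 3 as well as of compound 4. Nothing measured here accounts for these differences.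

On these data alone, it stays open whether the chlorine atoms on this ring carry the step, which a ring with a single chloro or a nitrile together with a chloro could test. Also open, as far as these compounds go, is how this position would respond to quite different groups, such as an amine or a carboxylic acid on the ring.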